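The source may hold more compounds than are shown below. What is called first, only, known or untested is meant among the compounds shown, and "the series" means these compounds.

Measured in a functional assay on HeLa cells (Homo sapiens) for antiproliferative activity, read by MTT assay, with a stated time of 72 h; a higher number here means a weaker inhibitor, a lower number a stronger inhibitor:
- compound 1 `O=C1O/C(=C\Cn2cc(-c3ccc(Br)cc3)nn2)C(OCc2ccccc2)=C1OCc1ccccc1`: 24300 nM
- compound 2 `CCCCCc1ccc(-c2cn(C[C@H](O)[C@H]3OC(=O)C(OCc4ccccc4)=C3OCc3ccccc3)nn2)cc1`: 8390 nM
- compound 3 `COc1ccc(-c2cn(C/C=C3\OC(=O)C(OCc4ccccc4)=C3OCc3ccccc3)nn2)cc1`: > 100000 nM

The value for compound 3 is a limit of the assay, not a number. Of the two true numbers, the lower belongs to compound 2, and the gap up to compound 1 lies beyond the scatter. These two compounds differ in more than one place, so that gap cannot be pinned on a single group.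

Compound 4 `CC(C)(C)c1cn(C[C@H](O)[C@H]2OC(=O)C(OCc3ccccc3)=C2OCc2ccccc2)nn1` has tert-butyl in place of 4-pentylphenyl on an aromatic carbon. For the measured compounds named here, only one measured step bears on this, and only loosely: an at least 4.1-fold higher number from compound 1 to compound 3 (0.61 log units; beyond the scatter), with methoxy in place of bromo on an aromatic carbon. That step shows that swapping one group can clearly raise the number. Compound 2 at 8390 nM already has the lowest value, so a rise looks more likely than a fall. Going by the values given here, no measured compound carries tert-butyl, so the uncertainty is wide.

The expected change is a 4.8-fold higher number from compound 2 to compound 4 (0.68 log units; beyond the scatter), towards a weaker inhibitor. For compound 4 the estimate is 40000 nM, with an expected range from 12000 nM to 90000 nM.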

Compound 4, half-maximal inhibitory concentration: 18300 nM
Compound 4: the middle estimate sits 2.2-fold (0.34 log units) above what was measured; the range from low to high includes it.
By their numbers in this assay, from the lowest: compound 2; then compounds 4 and 1 (each within the scatter of the next). At a limit, above all of these: compound 3.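

This is the first change shown at this aromatic carbon of the five-membered ring with 3 nitrogen, and it replaces the whole 4-pentylphenyl group rather than a single group on a phenyl ring. In this assay, tert-butyl, with 4 heavy atoms and no ring, in place of 4-pentylphenyl, with 11 heavy atoms and a six-membered aromatic ring, gives a 2.2-fold higher number from compound 2 to compound 4 (0.34 log units; beyond the scatter). So the step is real but modest: compound 4 still gives a measured number with no aromatic ring at this position, although nothing measured here explains the rise.

The compounds shown leave open whether the rise goes with losing the ring or with losing the pentyl chain. An unsubstituted phenyl or a straight pentyl chain at this carbon would help to separate the two.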